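The source may report more compounds than this note shows. Statements on the series, on what has been measured and on what is new or still open speak of the compounds shown alone.

Compound 2 `Nc1ncnc2c1nc(NCc1ccc(-c3ccccc3)c(OCCO)c1)n2[C@@H]1O[C@H](CO)[C@@H](O)[C@H]1O` gives 3100 nM in an assay on COS-7 cells for inhibition of sodium/nucleoside cotransporter 2 (Homo sapiens), read by scintillation counting; on this read-out lower numbers stand for stronger inhibition and higher numbers for weaker inhibition. Going by the values given here, compound 1 `NC(=O)COc1cc(CNc2nc3c(N)ncnc3n2[C@@H]2O[C@H](CO)[C@@H](O)[C@H]2O)ccc1-c1ccccc1`, the only other compound measured, gives 5500 nM. Among the compounds with values here, the one known step, a 1.8-fold lower number from compound 1 to compound 2 (0.25 log units; within the scatter), hydroxymethyl in place of carbamoyl on a saturated chain carbon bound to an oxygen on an aromatic ring, leaves compound 2 with the lowest of the two numbers yet not set apart from compound 1. Compound 3 `Nc1ncnc2c1nc(NCc1ccc(-c3ccccc3)c(OCCCCCO)c1)n2[C@@H]1O[C@H](CO)[C@@H](O)[C@H]1O` has not been measured. It differs from compound 2 by 3-hydroxypropyl in place of hydroxy on a saturated chain carbon, two bonds along the chain from an oxygen on an aromatic ring. Within the data shown here, no measured step lengthens a chain in this way, and the single step that exists, a 1.8-fold lower number from compound 1 to compound 2 (0.25 log units; within the scatter), stayed within the scatter, so there is no ground to expect movement in either direction. The expected step of no change at the digits printed from compound 2 to compound 3 (within the scatter) is therefore none beyond the scatter. For compound 3 the estimate is 3100 nM, in the range 1000 nM to 10000 nM.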

Compound 3, half-maximal inhibitory concentration: 1600 nM
Compound 3: middle estimate off by 1.9-fold (0.29 log units), on the high side; low and high end bracket the measured number.
By their numbers in this assay, from the lowest: compounds 3, 2 and 1 (each within the scatter of the next, the first and the last beyond it).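

In this assay, replacing 2-hydroxyethoxy with (5-hydroxypentyl)oxy gives a 1.9-fold lower number from compound 2 to compound 3 (0.29 log units; within the scatter), so this step alone does not separate the two chains. The series' first step beyond the scatter comes with the change of carbamoyl to 4-hydroxybutyl, a 3.4-fold lower number from compound 1 to compound 3 (0.54 log units; beyond the scatter). No measurement at hand accounts for either step.

On these data alone, it remains open whether the hydroxy of 5-hydroxypentyl contributes to the value of compound 3, which a plain pentyl chain, an amine or a carboxylic acid in its place could test. As far as these compounds go, it is also open whether a chain longer than 5-hydroxypentyl would take the number clear of the scatter relative to compound 2.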